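The source may report more compounds than this note shows. Statements on the series, on what has been measured and on what is new or still open speak of the compounds shown alone.

Compound 2 `C#CCN(c1ccc(Cl)cc1C)S(=O)(=O)c1cc(Cl)ccc1Cl` is a sulfonamide whose nitrogen carries a propargyl chain, with ethynyl on the saturated chain carbon bound to the sulfonamide nitrogen. In an ADME assay on A549 cells (Homo sapiens) for cytotoxicity, read by MTT assay (a lower number here means that less compound is tolerated, a higher number that more compound is tolerated), compound 2 gives > 5000 nM, which is a limit of the assay and not a number. Its closest measured relative, compound 1 `C=CCN(c1ccc(Cl)cc1C)S(=O)(=O)c1cc(Cl)ccc1Cl`, carries vinyl in that same place. In this assay compound 1 gives > 5000 nM, again a limit of the assay. The step that the two limits leave unreadable from compound 1 to compound 2 therefore cannot be read, both values sitting at the limit of > 5000 nM in this assay, at which 2 of the 2 values shown sit, so the two compounds cannot be told apart in this assay.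

Compound 3 `Cc1cc(Cl)ccc1N(CCO)S(=O)(=O)c1cc(Cl)ccc1Cl` differs from compound 2 by hydroxymethyl in place of ethynyl on a saturated chain carbon bound to a sulfonamide nitrogen. For the measured compounds named here, no measured step covers this change; the only step available, vinyl to ethynyl, is unreadable. What can be said is that both compounds seen so far are tolerated up to the limit. The step that the limit leaves unreadable from compound 2 to compound 3 is therefore expected to stay within the scatter, with compound 3 most likely also reaching the limit. Compound 3 is estimated to give 8000 nM, in the range 3000 nM to 30000 nM.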

Compound 3, half-maximal cytotoxic concentration: > 5000 nM
Compound 3: a limit, no number (the forecaster's own chance of this, stated with the estimate: 80%); the middle value does not contradict the limit.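

For the compounds shown here, no step among compound 1, compound 2 and compound 3 can be read, as each gives only a limit of the assay and not a number, so the three cannot be told apart in this assay: the limit of > 5000 nM in this assay, at which 3 of the 3 values shown sit. Still open, on these data alone, is whether vinyl, ethynyl and hydroxymethyl differ at all in how much compound the cells tolerate.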